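This account rests on a few compounds, and the source may have more. Where it says the series, first, only, none or still open, it means among the compounds named here.

Compound 3 `O=C(O)CC1CC(CNC(=O)CCCNc2nc3ccccc3[nH]2)=CCc2ccccc21` gives the lowest number of the three compounds measured in a functional assay on IGROV-1 cells (Homo sapiens) for inhibition (on this read-out lower numbers stand for stronger inhibition and higher numbers for weaker inhibition), at 1.8 nM. Compound 1 `O=C(O)CC1CC(CNC(=O)CCCNc2nccs2)=CCc2ccccc21` gives 40 nM and compound 2 `O=C(O)CC1CC(CNC(=O)CCNCc2ccccn2)=CCc2ccccc21` gives 2700 nM. Compound 4 `O=C(O)CC1CC(CNC(=O)CCCc2ccc3c(n2)NCCC3)=CCc2ccccc21` differs from compound 3 by a group of 10 heavy atoms (8 carbon, 2 nitrogen; one six-membered non-aromatic ring with 1 hetero atom, one six-membered aromatic ring with 1 hetero atom) in place of a group of 10 heavy atoms (7 carbon, 3 nitrogen; one five-membered aromatic ring with 2 hetero atoms, one six-membered aromatic ring of carbon only), on a saturated chain carbon, three bonds along the chain from a carbonyl carbon. Going by the values given here, no measured step swaps in this new group, so the two measured steps bear on it only loosely: a 22-fold lower number from compound 1 to compound 3 (1.35 log units; beyond the scatter), whereas a 68-fold higher number from compound 1 to compound 2 (1.83 log units; beyond the scatter). Both steps changed the same end of the chain and moved the number far, in opposite directions, so a sizeable shift either way is possible; a step of about a 1.4-fold higher number from compound 3 to compound 4 (0.14 log units; within the scatter) is expected. Compound 4 is therefore estimated at 2.5 nM, with a range from 0.4 nM to 15 nM.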

Compound 4, half-maximal inhibitory concentration: 6.9 nM
Estimate against measurement, compound 4: 2.8-fold (0.44 log units) below, within the range that was stated.
By their numbers in this assay, from the lowest: compound 3; then compound 4; then compound 1; then compound 2.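

In this assay the chain end proves open to a quite different two-ring group: there is a 3.8-fold higher number from compound 3 to compound 4 (0.58 log units; beyond the scatter) when the group with a six-membered non-aromatic ring and 1 hydrogen-bond donor replaces (1H-benzimidazol-2-yl)amino, which has 2. The same group still gives a 5.8-fold lower number from compound 1 to compound 4 (0.76 log units; beyond the scatter), so a five-membered aromatic ring is not needed for a low number here. Nothing available explains either step.

On these data alone, whether a plain naphthyl group at this place would serve equally well remains open. So does the effect of replacing the carboxylic acid with a tetrazole.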